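The compounds below may be only part of what the source reports. "The series", "measured", "known", "first", "only" and "open" are said of these compounds alone.

Compound 1 `CCOC(=O)/C(O)=C/C(=O)c1cn(Cc2cc(F)ccc2F)c2cccc(OC)c12`: 41200 nM
Compound 2 `CCOC(=O)/C(O)=C/C(=O)c1cn(Cc2c(F)cccc2F)c2cccc(OC)c12`: 63400 nM
Compound 3 `CCOC(=O)/C(O)=C/C(=O)c1cn(Cc2ccccc2F)c2cccc(OC)c12`: 63300 nM

In an ADME assay on MT4 cells (Homo sapiens) for cytotoxicity, read by MTT assay (on this read-out higher numbers stand for lower toxicity in this test and lower numbers for higher toxicity in this test), compound 3 gives 63300 nM, a number that sits among the other two, since the step of a 1.5-fold higher number from compound 1 to compound 3 (0.19 log units; within the scatter) and the step of a 1.0-fold lower number from compound 2 to compound 3 (0.00 log units; within the scatter) both stay within the usual scatter. Compound 4 `CCOC(=O)/C(O)=C/C(=O)c1cn(Cc2cc(F)cc(F)c2)c2cccc(OC)c12` differs from compound 3 only at the benzyl group: 3,5-difluorophenyl in place of 2-fluorophenyl on a saturated chain carbon bound to an aromatic nitrogen. For the measured compounds named here, the steps that bear on this are those that moved fluorine around the same ring, namely a 1.5-fold higher number from compound 1 to compound 2 (0.19 log units; within the scatter) and a 1.5-fold higher number from compound 1 to compound 3 (0.19 log units; within the scatter), and neither left the scatter. So no step beyond the scatter is expected here either, a 1.2-fold lower number from compound 3 to compound 4 (0.06 log units; within the scatter), and compound 4 is estimated to give 55000 nM, between 30000 nM and 100000 nM.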

Compound 4, half-maximal cytotoxic concentration: 34700 nM
Beside the measured number, compound 4's estimate is 1.6-fold (0.20 log units) above it; the range from low to high includes it.
By their numbers in this assay, from the lowest: compounds 4, 1, 3 and 2 (each within the scatter of the next).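

In this assay, 3,5-difluorophenyl at this place gives a 1.8-fold lower number from compound 3 to compound 4 (0.26 log units; within the scatter), a 1.8-fold lower number from compound 2 to compound 4 (0.26 log units; within the scatter) and a 1.2-fold lower number from compound 1 to compound 4 (0.07 log units; within the scatter), and all three steps stay within the scatter. With this fourth fluorine pattern, the compounds shown still give no sign that the number of fluorines or their arrangement on this ring matters for cytotoxicity in this test. Nothing measured here offers an explanation for these numbers. Open, going by these compounds, is whether a plain benzyl group with no fluorine would behave the same way. Also open, on these data alone, is whether an amine or a carboxylic acid on this ring would move the number beyond the scatter.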